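A few compounds are considered here, and "the series" means these few. Any claim that something is new, unique, unknown or untested is made for them only; others in the source may bear on it.

Working notes on the series. Compound 3 `CNC(=O)c1cc(Oc2ccc3nc(Nc4ccc(F)cc4)ncc3c2)ccn1` carries a 4-fluorophenyl on a nitrogen on an aromatic ring of the shared core. In an ADME assay on Caco-2 cells (Homo sapiens) for permeability, in the apical to basolateral direction (on this read-out higher numbers stand for higher permeability and lower numbers for lower permeability), compound 3 gives < 1 10^-6 cm/s, which is a limit of the assay and not a number. Compound 1 `CNC(=O)c1cc(Oc2ccc3nc(Nc4cccc(C(C)(C)C)c4)ncc3c2)ccn1` carries a 3-(tert-butyl)phenyl at the same place. In this assay compound 1 gives < 1 10^-6 cm/s, again a limit. Compound 2 `CNC(=O)c1cc(Oc2ccc3nc(Nc4ccccc4Br)ncc3c2)ccn1` carries a 2-bromophenyl there. In this assay compound 2 gives < 1 10^-6 cm/s, also a limit. Hence the step that the two limits leave unreadable from compound 1 to compound 2, the step that the two limits leave unreadable from compound 1 to compound 3 and the step that the two limits leave unreadable from compound 2 to compound 3 are all unreadable, as the limit of < 1 10^-6 cm/s in this assay, at which 3 of the 3 values shown sit, records. Compound 3 thus stands at the limit, alongside the two other measured compounds.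

Compound 4 `CNC(=O)c1cc(Oc2ccc3nc(Nc4ccc(OC(F)(F)F)cc4)ncc3c2)ccn1` differs from compound 3 by trifluoromethoxy in place of fluoro on an aromatic carbon. Among the measured compounds shown here, none of the measured steps yields a readable size that bears on this change; they show only that the three aryl groups tried so far all leave the value at the limit. The expectation for the step of a number no lower from compound 3 to compound 4 (the limit leaves the size open) is accordingly that compound 4 most likely remains at the limit, with a numerical reading being the less likely outcome. Compound 4 is estimated at 1 10^-6 cm/s, with a range of 0.3 10^-6 cm/s to 4 10^-6 cm/s.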

Compound 4, apparent permeability: < 1 10^-6 cm/s
Compound 4: only a limit was reported; the forecaster's own chance of this, stated with the estimate: 60%; the middle value lies on the limit itself.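

Compound 4 also returns a limit and not a number in this assay, so no step among compound 1, compound 2, compound 3 and compound 4 can be read, as all four sit at the same limit: the limit of < 1 10^-6 cm/s in this assay, at which 4 of the 4 values shown sit.

The compounds shown leave open whether these four differ at all on this read-out, and how large the step from fluoro to trifluoromethoxy is.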